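Trimming a Benzyl Selenide to Methyl in a Cytotoxicity Series

This account rests on a few compounds, and the source may have more. Where it says the series, first, only, none or still open, it means among the compounds named here.

Three related compounds have been tested in a functional assay on PC-3 cells (Homo sapiens) for cytotoxicity, read by MTT assay, with a stated time of 72 h; a lower number here means that less compound is tolerated, a higher number that more compound is tolerated. Compound 1 `CS/C(=N\C(=O)c1csc([N+](=O)[O-])c1)NC(=O)c1csc([N+](=O)[O-])c1` carries a methylthio group on the carbon with a double bond to nitrogen; in this assay compound 1 gives > 100000 nM, which is a limit of the assay and not a number. Compound 2 `O=C(/N=C(/NC(=O)c1ccno1)[Se]Cc1ccccc1)c1ccno1` carries a benzylselenyl group on a different core; in this assay compound 2 gives > 100000 nM, also a limit. Compound 3 `O=C(/N=C(/NC(=O)c1csc([N+](=O)[O-])c1)[Se]Cc1ccccc1)c1csc([N+](=O)[O-])c1` joins the benzylselenyl group to the core of compound 1; in this assay compound 3 gives > 100000 nM, again a limit. All three values sit at the limit of > 100000 nM in this assay, at which 3 of the 3 values shown sit. Compound 3 therefore stands at the edge of what this assay can report, and the step that the two limits leave unreadable from compound 1 to compound 3 has no readable size. Compound 4 `C[Se]/C(=N\C(=O)c1csc([N+](=O)[O-])c1)NC(=O)c1csc([N+](=O)[O-])c1` differs from compound 3 by hydrogen in place of phenyl on a saturated chain carbon bound to a selenium atom. For the measured compounds named here, no measured step with a readable size bears on this change, and every compound so far sits at the limit, so no movement beyond the scatter is expected for compound 4 in this assay. The step that the limit leaves unreadable from compound 3 to compound 4 is expected to be essentially none. Compound 4 is estimated at 200000 nM, with a range from 60000 nM to 700000 nM, and the assay most likely reports only a limit again.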

Compound 4, concentration lethal to 50% of the cells: > 100000 nM
Compound 4: no number, only a limit; the forecaster's own chance of this, stated with the estimate: 85%; the middle value is on the limit's open side.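

Compound 4 gives > 100000 nM as a limit of the assay and not a number. For the compounds shown here, no step from compound 3 or from compound 1 to compound 4 can be read, as every compound shown sits at the same edge: the limit of > 100000 nM in this assay, at which 4 of the 4 values shown sit. The compounds shown leave open whether benzyl to methyl, or any other change among them, affects cytotoxicity at all.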